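Two limits and a longer chain

This account rests on a few compounds, and the source may have more. Where it says the series, first, only, none or still open, it means among the compounds named here.

Compound 1 `CSc1nc(N)nc2c1ncn2/C=C1/CC1(CO)CO`: > 20000 nM
Compound 2 `CC(C)Sc1nc(N)nc2c1ncn2/C=C1/CC1(CO)CO`: > 20000 nM

Both entries come from an ADME assay on BCBL1 cells (Homo sapiens) for cytotoxicity, with a stated time of 7 days (a higher number here means that more compound is tolerated, a lower number that less compound is tolerated), and neither is a number. Compound 1 gives > 20000 nM, which is a limit of the assay. Compound 2 gives > 20000 nM, which is also a limit. So compound 2 has no exact position, and the record so far is the limit of > 20000 nM in this assay, at which 2 of the 2 values shown sit.

The next molecule, compound 3 `CCCCCCOc1nc(N)nc2c1ncn2/C=C1/CC1(CO)CO`, carries hexyloxy in place of isopropylsulfanyl on an aromatic carbon. Here the group changes as a whole, oxygen taking the place of sulfur and a hexyl chain that of the isopropyl.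

Going by the values given here, only one measured step bears on this change: a step that the two limits leave unreadable from compound 1 to compound 2. It swapped isopropyl for methyl on a sulfur, and it has no size that could be carried over. Among the compounds with values here, no measured step therefore points to a large shift. If there is any shift, less compound tolerated is the more likely direction, since both known values sit at the limit. The expected change is an at least 1.1-fold lower number from compound 2 to compound 3 (0.07 log units; that floor lies within the scatter). The estimate for compound 3 is 17000 nM, with an expected range of 7000 nM to 20000 nM.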

Compound 3, half-maximal cytotoxic concentration: > 20000 nM
Compound 3 ended at the assay's limit (the forecaster's own chance of this, stated with the estimate: 60%); middle value at least 1.1-fold (0.07 log units) away from the limit.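

In this assay compound 3 gives > 20000 nM as a limit and not a number, so none of the steps among compound 1, compound 2 and compound 3 can be read. Going by these compounds, how much of each compound the cells tolerate, and whether methylsulfanyl, isopropylsulfanyl and hexyloxy differ at all in this respect, remains open.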